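Amide variation on a shared core in a paw-edema assay

A few compounds are considered here, and "the series" means these few. Any claim that something is new, unique, unknown or untested is made for them only; others in the source may bear on it.

The measured compounds and their values:
Compound 1, `CCN(CC)C(=O)CC1CCc2cc(OC)c(OC)cc21`: 37.7%
Compound 2, `COc1cc2c(cc1OC)C(CC(=O)NC(C)(C)C)CC2`: 33.3%
Compound 3, `CCCCCCNC(=O)CC1CCc2cc(OC)c(OC)cc21`: 44.6%

Three amides built on one core were tested in a functional assay on the whole organism (strain Wistar) for inhibition, with Rattus norvegicus as the target, read by paw edema, with stated times of 60 min and 3 h, at a dose of 100 mg/kg by the oral route; a lower number here means less inhibition, a higher number more inhibition at the dose given (going by the name of the read-out). Compound 1 carries a diethylamino group on the carbonyl carbon, compound 2 a (tert-butyl)amino group, and compound 3 a hexylamino group. Compound 3 gives the highest number of the three, but its nearest neighbour is compound 1, which lies within the scatter; only compound 2 sits beyond it, as the step of a number 11.3 percentage points higher from compound 2 to compound 3 (beyond the scatter) shows. The other steps, a number 4.4 percentage points lower from compound 1 to compound 2 (within the scatter) and a number 6.9 percentage points higher from compound 1 to compound 3 (within the scatter), are both within the scatter.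

Compound 4, `COc1cc2c(cc1OC)C(CC(=O)NCc1ccccc1)CC2`, differs from compound 3 in one place: phenyl in place of pentyl on a saturated chain carbon bound to an amide-type nitrogen. Among the compounds with values here, none of the measured steps exchanges a chain for an aromatic ring, so the relevant comparisons are the two changes on the amide nitrogen already seen, one modest and the others within the scatter. Compound 4 is therefore expected to sit close to compound 3, with the step of a number 2.6 percentage points lower from compound 3 to compound 4 (within the scatter) not beyond the scatter. Compound 4 is estimated at 42%, with a range from 28% to 56%.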

Compound 4, a percentage reported as inhibition, in the whole organism at one dose (the size of the read-out at that dose, not a potency): 14.5%
The estimate for compound 4 lay 27.5 percentage points above the measured number, outside the stated range (below it).
By their numbers in this assay, from the lowest: compound 4; then compounds 2, 1 and 3 (each within the scatter of the next, the first and the last beyond it).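

In this assay, the three compounds with saturated carbon groups on the amide nitrogen gave no hint that this position could cost so much, yet benzyl brings a far larger change: a number 30.1 percentage points lower from compound 3 to compound 4 (beyond the scatter), a number 18.8 percentage points lower from compound 2 to compound 4 (beyond the scatter) and a number 23.2 percentage points lower from compound 1 to compound 4 (beyond the scatter). Compound 4 therefore has the lowest number of the four, beyond the scatter of each of the others, and the exchange of pentyl for phenyl on a saturated chain carbon bound to an amide-type nitrogen is the largest step in the set. Nothing available explains this fall.

On these data alone, whether it belongs to the aromatic ring itself remains open, and cyclohexylmethyl on the amide nitrogen would test that. Also open, as far as these compounds go, is how a phenylethyl group, with a longer chain before the ring, would read in this assay.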